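Turning the amide round: from compound 2 to compound 3

This account rests on a few compounds, and the source may have more. Where it says the series, first, only, none or still open, it means among the compounds named here.

Compound 1 `O=C(O)c1ccc2noc(-c3ccc(Oc4ccccn4)cc3)c2c1` gives 1190 nM in an assay for inhibition of inositol hexakisphosphate kinase 2 (Homo sapiens), read by colorimetric assay, coupled enzyme assay and malachite green, with a stated time of 120 min, in the presence of a further agent that is not named here; on this read-out lower numbers stand for stronger inhibition and higher numbers for weaker inhibition; compound 2 `CC(C)C(=O)Nc1ccc(-c2onc3ccc(C(=O)O)cc23)cc1` gives 820 nM in this assay.

Compound 2 has the lower of the two numbers shown, but its nearest neighbour, compound 1, is separated from it by a 1.5-fold lower number from compound 1 to compound 2 (0.16 log units; within the scatter), so the two cannot be ranked. Compound 3 `CC(C)NC(=O)c1ccc(-c2onc3ccc(C(=O)O)cc23)cc1` is the unmeasured partner of compound 2, and the difference between them is isopropylcarbamoyl in place of (isopropylcarbonyl)amino on an aromatic carbon: the two have the same atoms, joined differently, and the shared core is untouched.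

For the measured compounds named here, the only step measured so far, a 1.5-fold lower number from compound 1 to compound 2 (0.16 log units; within the scatter), concerns a different exchange at the same aromatic carbon and does not bear directly on turning the amide round. Going by the values given here, no pair among the measured compounds shows what this reversal does. Among the compounds with values here, with a step of that sort left unmeasured and the one known step within the scatter, the expected outcome for compound 3 is a number close to that of compound 2, with no movement beyond the scatter in either direction.

Compound 3 is therefore estimated at 900 nM, with a range from 300 nM to 2700 nM, which corresponds to an expected 1.1-fold higher number from compound 2 to compound 3 (0.04 log units; within the scatter).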

Compound 3, half-maximal inhibitory concentration: 350 nM
Estimate against measurement, compound 3: 2.6-fold (0.41 log units) above; the range from low to high includes it.
By their numbers in this assay, from the lowest: compound 3; then compounds 2 and 1 (each within the scatter of the next).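

In this assay, for the compounds shown here, the orientation of the amide on this aromatic carbon, para to a large group, makes a measurable difference: with the same atoms joined differently, isopropylcarbamoyl in place of (isopropylcarbonyl)amino gives a 2.3-fold lower number from compound 2 to compound 3 (0.37 log units; beyond the scatter), the one step from compound 2 that lies beyond the scatter. Exchanging (pyridin-2-yl)oxy for isopropylcarbamoyl gives a 3.4-fold lower number from compound 1 to compound 3 (0.53 log units; beyond the scatter), so compound 3 stands apart from both of the other compounds, whereas the earlier exchange of (pyridin-2-yl)oxy for (isopropylcarbonyl)amino did not separate compound 1 from compound 2. No independent measurement is available to account for the difference between the two amide orientations.

The compounds shown leave open whether the lower number of compound 3 depends on the isopropyl group, which a cyclopropyl group, a tert-butyl group or a longer chain on the amide nitrogen would test, and whether an amide with a second carbon substituent on that nitrogen would behave the same way. They also leave open how much the shared core contributes through its carboxylic acid, which a methyl ester or a tetrazole in its place would begin to address.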